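Ester Series: Limit Values in the Cytotoxicity Screen

The compounds below may be only part of what the source reports. "The series", "measured", "known", "first", "only" and "open" are said of these compounds alone.

Measured so far in an ADME assay on Raji cells (Homo sapiens) for cytotoxicity, read by CellTiter-Glo and resazurin assay, with a stated time of 72 h; a higher number here means that more compound is needed for the effect, a lower number that less compound is needed:
- compound 1 `CC(C)N(Cc1cccc(OCCCCCC(=O)O)c1)C(=O)c1ccc(-c2cccc(O)c2)cc1`: > 26000 nM
- compound 2 `CCOC(=O)CCCCCOc1cccc(CN(C(=O)c2ccc(-c3cccnc3)cc2)C(C)C)c1`: > 26000 nM
- compound 3 `CCOC(=O)CCCCCOc1cccc(CN(C(=O)c2ccc(-c3ccc4c(c3)OCCO4)cc2)C(C)C)c1`: > 24400 nM

Compound 3 stands only at a limit of this assay, > 24400 nM, not at a number. Compound 1 likewise stands at a limit, > 26000 nM. Compound 2 also sits at a limit, > 26000 nM. Among the measured compounds shown here, the single computed step, a step that the two limits leave unreadable from compound 2 to compound 3, cannot be read because both of its ends are limits; see the limit of > 24400 nM in this assay, at which 1 of the 3 values shown sits, and (the limit of > 26000 nM in this assay, at which 2 of the 3 values shown sit).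

The next compound, compound 4 `CCOC(=O)CCCCCOc1cccc(CN(C(=O)c2ccc(-c3cccc(O)c3)cc2)C(C)C)c1`, differs from compound 3 in one place: 3-hydroxyphenyl in place of 2,3-dihydro-1,4-benzodioxin-6-yl on an aromatic carbon. For the measured compounds named here, compound 1 carries the same 3-hydroxyphenyl group and also reaches only a limit, so no measured step shows any movement in this assay anywhere. Going by the values given here, with every value at a limit, no direction for the step from compound 3 to compound 4 can be derived; the expectation is that compound 4 will again come out at a limit, with a step that the limit leaves unreadable from compound 3 to compound 4 as the estimated step. Compound 4 is therefore expected at 30000 nM, within the range 15000 nM to 80000 nM, most likely reported only as a limit.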

Compound 4, half-maximal effective concentration: > 26000 nM
Compound 4: a limit, no number; the forecaster's own chance of this, stated with the estimate: 85%; the middle value lies beyond the limit too.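

Compound 4 stands only at a limit in this assay, > 26000 nM. Among the compounds shown here, no step from compound 1, compound 2 or compound 3 to compound 4 can be read, as each has a limit at both ends. The compounds shown leave open at what concentration any of the four reaches the half-maximal effect, and whether the exchanged groups alter it.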